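Moving the pyridine nitrogen: what stability to expect

The source may report more compounds than this note shows. Statements on the series, on what has been measured and on what is new or still open speak of the compounds shown alone.

Compound 1 `N#C/N=C(\NCc1ccc(S(=O)(=O)c2ccccc2)cc1)Nc1cccnc1` — 83%
Compound 2 `N#C/N=C(\NCc1ccc(S(=O)(=O)N2CC3CCC(C2)O3)cc1)Nc1ccncc1` — 60%

Both were tested in an ADME assay (liver) for metabolic stability, with Liver microsome (Homo sapiens) as the target, using microsomes, with a stated time of 30 min, tested at 1 uM; a higher number here means that more of the compound is left, a lower number that less of the compound is left. Compound 2 stands at the lower of the two numbers, and its gap to compound 1 lies beyond the usual scatter. The two differ in more than one place, so no single change can be credited with that gap.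

Compound 3 `N#C/N=C(\NCc1ccc(S(=O)(=O)N2CC3CCC(C2)O3)cc1)Nc1cccnc1` differs from compound 2 in one place only: pyridin-3-yl in place of pyridin-4-yl on an amine nitrogen. Among the compounds with values here, no pair of measured compounds isolates this change, so the expectation is loose. For compound 3 the expected step is a number 8 percentage points higher from compound 2 to compound 3 (within the scatter), slightly upward, within or barely beyond the scatter. The estimate for compound 3 is 68%, ranging from 50% to 85%.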

Compound 3, percent of the compound remaining: 52%
Compound 3: the middle estimate sits 16 percentage points above what was measured; the range from low to high includes it.
By their numbers in this assay, from the lowest: compounds 3 and 2 (each within the scatter of the next); then compound 1.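

Moving the ring nitrogen, with pyridin-3-yl in place of pyridin-4-yl on an amine nitrogen, gives a number 8 percentage points lower from compound 2 to compound 3 (within the scatter) in this assay, so this change has no clear effect on stability here. The change on the sulfonyl sulfur counts for much more, with a number 31 percentage points lower from compound 1 to compound 3 (beyond the scatter) when the two-ring group of compound 3 replaces the all-carbon aromatic ring of compound 1. Nothing available explains either step.

From the compounds shown here alone, it remains open whether pyridin-2-yl would match these results. A plain morpholine on the sulfonyl sulfur could also show whether the full two-ring group is needed for this large step.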